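A few compounds are considered here, and "the series" means these few. Any claim that something is new, unique, unknown or untested is made for them only; others in the source may bear on it.

Measured compounds:
- compound 1, `CS(=O)(=O)c1cnc(O[C@H]2CC[C@H](OC3CCN(C(=O)OC4CCOC4)CC3)CC2)cn1`, gives 109%
- compound 2, `CS(=O)(=O)c1cnc(O[C@H]2CC[C@H](OC3CCN(C(=O)C4(C(F)(F)F)CCCC4)CC3)CC2)cn1`, gives 124%
- compound 3, `CS(=O)(=O)c1cnc(O[C@H]2CC[C@H](OC3CCN(CC4(C(F)(F)F)CCCC4)CC3)CC2)cn1`, gives 88%

In a functional assay on isolated protein for agonist activity at Glucose-dependent insulinotropic receptor (Rattus norvegicus), read by HTRF and cAMP accumulation (on this read-out lower numbers stand for smaller maximal responses and higher numbers for larger maximal responses), compound 3 stands lowest of the three measured numbers. Its nearest neighbour is compound 1, as the step of a number 21 percentage points lower from compound 1 to compound 3 (beyond the scatter) shows, and the furthest is compound 2, as the step of a number 36 percentage points lower from compound 2 to compound 3 (beyond the scatter) shows. The step of a number 15 percentage points higher from compound 1 to compound 2 (beyond the scatter) lies between the two compounds that carry a carbonyl on the ring nitrogen.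

Compound 4, `CC(F)Cc1nc(CN2CCC(O[C@H]3CC[C@H](Oc4cnc(S(C)(=O)=O)cn4)CC3)CC2)no1`, has not yet been measured. It differs from compound 3 by a group of 9 heavy atoms (5 carbon, 2 nitrogen, 1 oxygen, 1 fluorine; one five-membered aromatic ring with 3 hetero atoms) in place of a group of 9 heavy atoms (6 carbon, 3 fluorine; one five-membered non-aromatic ring of carbon only), on a saturated chain carbon bound to an amine nitrogen in a ring. Within the data shown here, no measured step changes the group at this place: the two steps that end at compound 3 both alter what sits on the amine nitrogen itself, and both are downward and beyond the scatter. They give no direct guide for a swap on the saturated chain carbon, so the expected step of a number 12 percentage points higher from compound 3 to compound 4 (beyond the scatter) is set as a modest rise, with wide uncertainty. Compound 4 is therefore estimated at 100% in this assay, in a range from 75% to 125%.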

Compound 4, largest response reached (Emax), in percent of the reference or control that the assay uses: 114%
For compound 4 the middle estimate is 14 percentage points below the measured one, and the stated range covers the measured number.
By their numbers in this assay, from the lowest: compound 3; then compounds 1, 4 and 2 (each within the scatter of the next, the first and the last beyond it).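

In this assay, the 5-(2-fluoropropyl)-1,2,4-oxadiazol-3-yl group on the saturated chain carbon bound to the amine nitrogen in a ring gives a number 26 percentage points higher from compound 3 to compound 4 (beyond the scatter), so the group at this place alone separates these two compounds by more than the scatter. A carbonyl on the ring nitrogen is also not required for a response in the range of the carbonyl compounds, as a number 10 percentage points lower from compound 2 to compound 4 (within the scatter) and a number 5 percentage points higher from compound 1 to compound 4 (within the scatter) show, although compound 3 also lacks that carbonyl and stays apart from compound 4. No evidence is available that accounts for this difference.

The compounds shown leave open whether the fluorine matters, since a plain propyl chain on the oxadiazole cannot be compared with the 2-fluoropropyl chain. They also leave open whether the oxadiazole could give way to a 1,2,4-triazole.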